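Butyl to Cyclohexyl: What Compound 4 Should Show

The source may report more compounds than this note shows. Statements on the series, on what has been measured and on what is new or still open speak of the compounds shown alone.

In an ADME assay on RD cells (Homo sapiens) for cytotoxicity, read by MTT assay, with a stated time of 3 days (on this read-out higher numbers stand for lower toxicity in this test and lower numbers for higher toxicity in this test), compound 1 `CC[C@H](CCn1cncn1)c1ccccc1` gives 99.8 ug/mL. Compound 2 `CCCC[C@H](CCn1cncn1)c1ccccc1` gives 48.3 ug/mL, and compound 3 `CCCC[C@@H](CCn1cncn1)c1ccccc1` gives 47.5 ug/mL. The chain-lengthening step a 2.1-fold lower number from compound 1 to compound 2 (0.32 log units; beyond the scatter) was modest but beyond the scatter, whereas a 1.0-fold lower number from compound 2 to compound 3 (0.01 log units; within the scatter) stayed within it, as fits (the fact that compounds 2 and 3 differ only in the configuration as drawn). Compound 2 thus stands second highest of the three numbers, hardly apart from compound 3 and clearly below compound 1. Compound 4 `c1ccc([C@@H](CCn2cncn2)C2CCCCC2)cc1` differs from compound 2 by cyclohexyl in place of butyl on a saturated chain carbon bound to an aromatic carbon and a saturated chain carbon. Because the step of a 2.1-fold lower number from compound 1 to compound 2 (0.32 log units; beyond the scatter) moved modestly lower when the chain grew, a further modest move lower is anticipated for compound 4. The expected step is a 1.6-fold lower number from compound 2 to compound 4 (0.21 log units; within the scatter). Compound 4 is therefore estimated at 30 ug/mL, within 14 ug/mL to 65 ug/mL.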

Compound 4, half-maximal cytotoxic concentration: 9.2 ug/mL
Beside the measured number, compound 4's estimate is 3.3-fold (0.51 log units) above it; measured number below the stated range.
By their numbers in this assay, from the lowest: compound 4; then compounds 3 and 2 (each within the scatter of the next); then compound 1.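

At this saturated chain carbon, cyclohexyl in place of butyl brings a 5.3-fold lower number from compound 2 to compound 4 (0.72 log units; beyond the scatter), and cyclohexyl in place of ethyl brings an 11-fold lower number from compound 1 to compound 4 (1.04 log units; beyond the scatter). In this assay, lower numbers mean higher toxicity, so the position can shift toxicity much further than the change from ethyl to butyl suggested. Nothing shown here explains this drop.

The compounds shown leave open whether the ring itself or the larger group drives the change. A hexyl chain or a cyclopentyl ring at this carbon could help separate the two.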